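Chloro in place of nitro: expected cytotoxicity of compound 4

The source may hold more compounds than are shown below. What is called first, only, known or untested is meant among the compounds shown, and "the series" means these compounds.

Measured compounds:
compound 1, `COc1ccc(C2SCC(=O)N2CCN2CCCCC2)cc1`: 100%
compound 2, `O=C1CSC(c2ccc([N+](=O)[O-])cc2)N1CCN1CCCCC1`: 100%
compound 3, `COc1cccc(C2SCC(=O)N2CCN2CCCCC2)c1`: 100%

In an ADME assay on Vero cells (Chlorocebus sabaeus) for cytotoxicity, read by neutral red uptake, tested at 12.3 ug/mL (a higher number here means a weaker effect of the compound at the concentration tested, a lower number a stronger effect), compound 1 gives 100%, compound 2 gives 100% and compound 3 gives 100%. Compound 2 thus stands level with compounds 1 and 3 at the digits shown. For the measured compounds named here, the only measured step that changes a single place, no change at the digits printed from compound 1 to compound 2 (within the scatter), lies within the scatter; it exchanged the methoxy group for the nitro group that the next change now removes. Compound 4, `O=C1CSC(c2ccc(Cl)cc2)N1CCN1CCCCC1`, differs from compound 2 by chloro in place of nitro on an aromatic carbon. Going by the values given here, since the one step touching this position, no change at the digits printed from compound 1 to compound 2 (within the scatter), was flat, no change beyond the scatter is expected in this assay. The expected step is no change at the digits printed from compound 2 to compound 4 (within the scatter). Compound 4 is therefore estimated at 100%, with a range from 85% to 100%.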

Compound 4, a percentage reported as activity, at one concentration (the size of the read-out at that concentration, not a potency): 90%
The estimate for compound 4 lay 10 percentage points above the measured number; low and high end bracket the measured number.
By their numbers in this assay, from the lowest: compounds 4, 1, 2 and 3 (each within the scatter of the next).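

In this assay chloro on this aromatic carbon, para to a large group, gives a number 10 percentage points lower from compound 2 to compound 4 (within the scatter) and a number 10 percentage points lower from compound 1 to compound 4 (within the scatter). Chloro thus joins nitro and methoxy as a third group at this place, and neither of its steps leaves the scatter, so the flat picture from the single earlier step now holds across all three groups. Nothing available accounts for the size of these steps. Going by these compounds, whether an amine or a carboxylic acid at this place would also stay within the scatter remains open.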